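Swapping the Sulfonyl Substituent Across Two Amide Cores

The source may hold more compounds than are shown below. What is called first, only, known or untested is meant among the compounds shown, and "the series" means these compounds.

Compound 1 `C=C(CC)C(=O)c1ccc(OCC(=O)N2CCN(S(=O)(=O)c3cccc4cccnc34)CC2)c(Cl)c1Cl` and compound 2 `C=C(CC)C(=O)c1ccc(OCC(=O)N2CCN(S(=O)(=O)C3CCCCC3)CC2)c(Cl)c1Cl` share one core, while compound 3 `C=C(CC)C(=O)c1ccc(OCC(=O)NC2CCN(S(=O)(=O)c3cccc4cccnc34)CC2)c(Cl)c1Cl` and compound 4 `C=C(CC)C(=O)c1ccc(OCC(=O)NC2CCN(S(=O)(=O)C3CCCCC3)CC2)c(Cl)c1Cl` share another; the difference between the two cores is not broken down here. In a functional assay on HL-60 cells (Homo sapiens) for cytotoxicity, read by luminescence (a higher number here means a weaker inhibitor, a lower number a stronger inhibitor), compound 1 gives 2980 nM and compound 2 gives 2320 nM, a step of a 1.3-fold lower number from compound 1 to compound 2 (0.11 log units; within the scatter) brought about by cyclohexyl in place of quinolin-8-yl on a sulfonyl sulfur. Compound 3 gives 970 nM in this assay, the lowest of the three numbers, with both compound 1 and compound 2 lying beyond the scatter above it.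

Compound 4 differs from compound 3 by cyclohexyl in place of quinolin-8-yl on a sulfonyl sulfur. For the measured compounds named here, this is the same change as the one made from compound 1 to compound 2, and it was made there on a place described in identical words. Since that earlier step stayed within the scatter, the step from compound 3 to compound 4 in this assay is expected to be small as well, estimated at a 1.2-fold lower number from compound 3 to compound 4 (0.09 log units; within the scatter). On that basis compound 4 is expected to give about 780 nM in this assay, most likely between 350 nM and 1700 nM.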

Compound 4, half-maximal inhibitory concentration: 2940 nM
Beside the measured number, compound 4's estimate is 3.8-fold (0.58 log units) below it; measured number above the stated range.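

In this assay, putting cyclohexyl in place of quinolin-8-yl on a sulfonyl sulfur gives a 3.0-fold higher number from compound 3 to compound 4 (0.48 log units; beyond the scatter), so the change does not carry over evenly from one core to the other: the same change on two cores in this assay, a 1.3-fold lower number (0.11 log units; within the scatter) from compound 1 to compound 2 and a 3.0-fold higher number (0.48 log units; beyond the scatter) from compound 3 to compound 4, 3.9-fold (0.59 log units) apart, beyond the scatter of two such steps

On the core of compound 1, the two groups cannot be told apart in this assay, whereas on the core of compound 3, quinolin-8-yl goes with the lower number, and a result for this change on one core is therefore a poor guide to its result on the other. The comparison rests on a single pair of compounds on each core, and it does not show which feature of the two cores separates the outcomes or whether the gap extends to other groups at this place.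

The compounds shown leave open how a phenyl, a straight butyl chain or a morpholine on the sulfonyl sulfur would behave on each core. They also leave open whether such groups would follow quinolin-8-yl or cyclohexyl on the core of compound 3.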